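From pentyl to cyclohexyl in a growth inhibition series

This account rests on a few compounds, and the source may have more. Where it says the series, first, only, none or still open, it means among the compounds named here.

Compound 1 `CCOC(=O)C#CC(O/C=C/C(=O)OCC)C(C)C`: 3000 nM
Compound 2 `CCCCCC(C#CC(=O)OC)O/C=C/C(=O)OC`: 1900 nM
Compound 3 `C#CC(O/C=C/C(=O)OC)c1ccccc1`: 26000 nM

These three compounds were tested in a functional assay on HBL-100 cells (Homo sapiens) for antiproliferative activity, read by sulforhodamine B assay, with a stated time of 48 h; on this read-out lower numbers stand for stronger inhibition of growth and higher numbers for weaker inhibition of growth. Compound 2 stands level with compound 1, within the scatter, while compound 3 lies beyond the scatter from both, on the side of weaker inhibition of growth. Among the compounds with values here, no two measured compounds differ in one place only, so no single change has yet been measured directly.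

The account now moves from compound 2 to compound 4 `COC(=O)C#CC(O/C=C/C(=O)OC)C1CCCCC1`: cyclohexyl in place of pentyl on a saturated chain carbon bound to an oxygen on an unsaturated carbon and a triple-bonded carbon. In this assay no step beyond the scatter is expected. That expectation rests on compound 1 at 3000 nM and compound 2 at 1900 nM, which differ at this place and in their esters yet remain within the scatter of each other. Compound 3, at 26000 nM, differs in more than one place and keeps the expected range wide on the upper side. The estimated change is a 1.3-fold higher number from compound 2 to compound 4 (0.12 log units; within the scatter), a small move toward a higher number. For compound 4 the estimated value is 2500 nM, with an expected range from 900 nM to 7000 nM.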

Compound 4, concentration for 50% growth inhibition: 2500 nM
Compound 4: the middle estimate sits on the measured number at the digits printed; measured number inside the range.
By their numbers in this assay, from the lowest: compounds 2, 4 and 1 (each within the scatter of the next); then compound 3.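

Within the data shown here, compound 2 and compound 4 give the first direct reading at this position: in this assay, cyclohexyl in place of pentyl on a saturated chain carbon bound to an oxygen on an unsaturated carbon and a triple-bonded carbon gives a 1.3-fold higher number from compound 2 to compound 4 (0.12 log units; within the scatter) and so the two compounds stand level. Among these compounds, for this pair, then, an open chain and a six-membered non-aromatic ring of carbon only read alike at this place, which the earlier compounds, all differing in more than one place, could not show. Nothing available here bears on why the two read alike.

Still open, on these data alone, is whether a longer chain, or a cyclohexyl ring carrying an amine or a carboxylic acid, would also stand level with compound 2. A single pair also cannot tell whether the same exchange would read alike with other esters on the shared core.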